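The source may hold more compounds than are shown below. What is called first, only, known or untested is meant among the compounds shown, and "the series" means these compounds.

Compound 3 `O=C(CSc1snnc1-c1ccc(Br)cc1Br)Nc1ccccc1Cl` is the parent here. In an ADME assay on MT4 cells (Homo sapiens) for cytotoxicity, read by MTT assay, with a stated time of 5 days (a lower number here means that less compound is tolerated, a higher number that more compound is tolerated), compound 3 gives > 240000 nM, which is a limit of the assay and not a number. Its neighbour compound 1 `O=C(CSc1snnc1-c1ccc(Br)cc1Br)Nc1ccccc1F` gives >= 27800 nM, again a limit. Compound 2 `Cc1cccc(C)c1NC(=O)CSc1snnc1-c1ccc(Br)cc1Br` gives >= 198000 nM, also a limit. Compound 4 `O=C(CSc1snnc1-c1ccc(Br)cc1Br)Nc1ccccc1` differs from compound 3 by hydrogen in place of chloro on an aromatic carbon. The steps that could guide this are a step that the two limits leave unreadable from compound 1 to compound 3, a step that the two limits leave unreadable from compound 1 to compound 2 and a step that the two limits leave unreadable from compound 2 to compound 3, each unreadable in size. All three values sit at limits, so no step size is known; the expected step is an at least 1.2-fold lower number from compound 3 to compound 4 (0.07 log units; that floor lies within the scatter), with no direction beyond the scatter. Compound 4 is therefore expected to show 200000 nM, estimated between 50000 nM and 300000 nM, most likely reported again as a limit.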

Compound 4, half-maximal cytotoxic concentration: 24800 nM
The estimate for compound 4 lay 8.1-fold (0.91 log units) above the measured number; the measured number lies below the stated range.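

The steps among compound 1, compound 2 and compound 3 cannot be read, but in this assay hydrogen in place of chloro on this aromatic carbon gives a readable one, an at least 9.6-fold lower number from compound 3 to compound 4 (0.98 log units; beyond the scatter). Phenyl in place of 2,6-dimethylphenyl likewise goes beyond the scatter, with an at least 7.9-fold lower number from compound 2 to compound 4 (0.90 log units; beyond the scatter). Hydrogen in place of fluoro does not join this pattern, as an at least 1.1-fold lower number from compound 1 to compound 4 (0.04 log units; that floor lies within the scatter) is only a floor within the scatter.

On these data alone, how far compound 1, compound 2 and compound 3 lie past their limits stays open. So does what a methoxy group or an amine in place of the chloro would give.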